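A few compounds are considered here, and "the series" means these few. Any claim that something is new, unique, unknown or untested is made for them only; others in the source may bear on it.

Compound 3 `COc1ccc(-c2nc(CNC(=O)c3cccnc3)sc2-c2ccc(OC)cc2)cc1` gives 25 nM in a functional assay with Oryctolagus cuniculus as the target; a lower number here means a stronger inhibitor, a higher number a weaker inhibitor. Compound 2 `C/N=C(/NC)Nc1nc(-c2ccc(OC)cc2)c(-c2ccc(OC)cc2)s1` gives 970 nM in this assay, so compound 3 holds the lowest of the two numbers, with a 39-fold lower number from compound 2 to compound 3 (1.59 log units; beyond the scatter). Compound 1 `COc1ccc(-c2nc(/N=C(\N)NC3CCCCC3)sc2-c2ccc(OC)cc2)cc1` gives only > 1000 nM in this assay, which is a limit of the assay rather than a number (the limit of > 1000 nM in this assay, at which 1 of the 3 values shown sits). Even so, an at least 40-fold lower number from compound 1 to compound 3 (1.60 log units; beyond the scatter). Compound 4 `COc1ccc(-c2nc(C(=O)N3CCCCC3)sc2-c2ccc(OC)cc2)cc1` carries (piperidin-1-yl)carbonyl in place of (((pyridin-3-yl)carbonyl)amino)methyl on an aromatic carbon. Going by the values given here, no measured step exchanges this group for a ring joined through a carbonyl; the two steps into compound 3 show only that its group sets it far apart from compound 1 and compound 2. Some loss back toward them is expected, so compound 4 is estimated at 150 nM, between 40 nM and 600 nM, a step of a 6.0-fold higher number from compound 3 to compound 4 (0.78 log units; beyond the scatter).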

Compound 4, half-maximal inhibitory concentration: > 1000 nM
Compound 4: only a limit was reported; the forecaster's own chance of this, stated with the estimate: 10%; middle value at least 6.6-fold (0.82 log units) from the limit.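

On this aromatic carbon, (piperidin-1-yl)carbonyl in place of (((pyridin-3-yl)carbonyl)amino)methyl gives an at least 40-fold higher number from compound 3 to compound 4 (1.60 log units; beyond the scatter), so the low number of compound 3 does not survive this exchange in this assay. Against the other neighbour the reading is only an at least 1.0-fold higher number from compound 2 to compound 4 (0.01 log units; that floor lies within the scatter), and the step between compound 1 and compound 4 cannot be read. The result for compound 4 is a limit of the assay, not a number: the limit of > 1000 nM in this assay, at which 2 of the 4 values shown sit.

This exchange alters the ring and its link to the core together, and the compounds shown do not separate the two. A plain aminomethyl group or a (phenylcarbonyl)aminomethyl group on this carbon would be needed to show which part carries the low number.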